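The source may hold more compounds than are shown below. What is called first, only, known or untested is meant among the compounds shown, and "the series" means these compounds.

Working notes on the series. Compound 3 `CC/N=C(\S)NCCCn1nc(-c2ccccc2)ccc1=O` is read in a functional assay on the whole organism with Rattus norvegicus as the target, at a dose of 100 mg/kg (on this read-out higher numbers stand for more inhibition at the one dose given (going by the name of the read-out) and lower numbers for less inhibition), where compound 3 gives 39%. Among the three measured compounds this is the lowest number, though its nearest neighbour compound 1 `C/N=C(/NC#N)NCCCn1nc(-c2ccccc2)ccc1=O`, which gives 40.5% in this assay, and compound 2 `C/N=C(/NC#N)NCCCCCn1nc(-c2ccccc2)ccc1=O`, which gives 47.6%, both sit within the scatter of it, so no order can be read from these three.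

Within the data shown here, the only measured step that touches compound 3 is a number 1.5 percentage points lower from compound 1 to compound 3 (within the scatter), a swap on an amine nitrogen that left the read-out where it was.

Compound 4 `C/N=C(\S)NCCCCCCn1nc(-c2ccccc2)ccc1=O` is not yet measured. Compared with compound 3 the change is a group of 8 heavy atoms (5 carbon, 2 nitrogen, 1 sulfur; no ring) in place of a group of 6 heavy atoms (3 carbon, 2 nitrogen, 1 sulfur; no ring), on a saturated chain carbon, three bonds along the chain from an aromatic nitrogen. Among the measured compounds shown here, no measured pair shows exactly this change. The closest comparison in the data is compound 1 against compound 2, which differ in chain length between the core and the amine nitrogen. In this assay compound 1 gives 40.5% and compound 2 gives 47.6%, and the two numbers lie close to each other.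

Given the flat step a number 1.5 percentage points lower from compound 1 to compound 3 (within the scatter) and the closeness of compound 1 and compound 2, a step of a number 5 percentage points higher from compound 3 to compound 4 (within the scatter) is expected, that is nothing beyond the scatter. Compound 4 is therefore estimated at 44% in this assay, with a range of 30% to 58%.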

Compound 4, a percentage reported as inhibition, in the whole organism at one dose (the size of the read-out at that dose, not a potency): 22.2%
Compound 4: middle estimate off by 21.8 percentage points, on the high side, outside the stated range (below it).
By their numbers in this assay, from the lowest: compound 4; then compounds 3, 1 and 2 (each within the scatter of the next).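

In this assay, among these compounds, the change on a saturated chain carbon, three bonds along the chain from an aromatic nitrogen, gives the first step that lies beyond the scatter, with a number 16.8 percentage points lower from compound 3 to compound 4 (beyond the scatter) for the group of 8 heavy atoms in place of the group of 6 heavy atoms. Two further readings, a number 18.3 percentage points lower from compound 1 to compound 4 (beyond the scatter) and a number 25.4 percentage points lower from compound 2 to compound 4 (beyond the scatter), point the same way, so compound 4 is the lowest of the four, and this position is not as flat as the three earlier numbers, which showed no order, had suggested. Nothing on hand bears on why the number falls at this position.

Open, from the compounds shown here alone, is whether the fall goes with the longer chain or with the sulfur-bearing end group: compound 4 differs from compound 1 and compound 2 in both, and a nitrile-bearing end group on the chain of compound 4 would separate the two. Also open, going by these compounds, is whether a still longer chain, or an amine at the end of the chain, would continue the fall or reverse it.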